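Shortening the Urea Side Chain from Ethyl to Methyl

The compounds below may be only part of what the source reports. "The series", "measured", "known", "first", "only" and "open" are said of these compounds alone.

Three small ureas built on one shared core have been measured in a functional assay on MCF7 cells (Homo sapiens) for inhibition; a higher number here means a weaker inhibitor, a lower number a stronger inhibitor. Among the compounds with values here, compound 3 `CCNC(=O)N1CC1C#N` carries an ethyl group on its urea nitrogen and gives 29000 nM in this assay, the only plain number among the three. Compound 1 `CC(C)(C)NC(=O)N1CC1C#N`, with a tert-butyl group in that place, gives > 300000 nM in this assay, which is a limit of the assay rather than a number. Compound 2 `N#CC1CN1C(N)=O`, with a bare hydrogen there, gives > 54000 nM in this assay, again a limit of the assay and not a number. Compound 3 therefore stands as the one fixed point from which any comparison must start.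

Compound 4 `CNC(=O)N1CC1C#N` has not yet been measured. It differs from compound 3 by hydrogen in place of methyl on a saturated chain carbon bound to an amide-type nitrogen. Within the data shown here, two measured steps bear on this change. Going from tert-butyl to ethyl gave an at least 10-fold lower number from compound 1 to compound 3 (1.01 log units; beyond the scatter). Going from hydrogen to ethyl gave an at least 1.8-fold lower number from compound 2 to compound 3 (0.26 log units; that floor lies within the scatter). Methyl sits between hydrogen and ethyl, so only a small upward move is expected, and for compound 4 that means an estimated step of a 1.4-fold higher number from compound 3 to compound 4 (0.14 log units; within the scatter). Compound 4 is therefore estimated at 40000 nM, expected to fall between 15000 nM and 110000 nM.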

Compound 4, half-maximal inhibitory concentration: 27000 nM
The estimate for compound 4 lay 1.5-fold (0.17 log units) above the measured number, and the stated range covers the measured number.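

Ethyl and methyl on the urea nitrogen cannot be told apart in this assay, with a 1.1-fold lower number from compound 3 to compound 4 (0.03 log units; within the scatter), so trimming this chain by its end carbon leaves no readable mark on the number. With methyl, as with ethyl, the step away from tert-butyl is large, an at least 11-fold lower number from compound 1 to compound 4 (1.04 log units; beyond the scatter), so the large gap is not special to compound 3, and this step can be read only as a floor because it rests on a limit: the limit of > 300000 nM in this assay, at which 1 of the 4 values shown sits. Against the bare hydrogen the picture stays unsettled, with an at least 2.0-fold lower number from compound 2 to compound 4 (0.30 log units; that floor lies within the scatter), so compound 4 does not show whether any chain on this nitrogen matters at all, because this step also rests on a limit: the limit of > 54000 nM in this assay, at which 1 of the 4 values shown sits.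

The compounds shown leave open where on the way from ethyl to tert-butyl the number starts to rise, which a propyl or isopropyl group on the same nitrogen would help to place. They also leave open how this nitrogen would respond to a cyclopropyl group or to a chain ending in an amine or a carboxylic acid.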